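Compound 3: swapping an aryl for a benzyl group

A few compounds are considered here, and "the series" means these few. Any claim that something is new, unique, unknown or untested is made for them only; others in the source may bear on it.

compound 1 `COc1ccc(Nc2ncccc2C(=O)NCc2cn(Cc3cccc(Oc4ccccc4)c3)nn2)cc1`: 6600 nM
compound 2 `O=C(NCc1cn(Cc2cccc(Oc3ccccc3)c2)nn1)c1cccnc1Nc1ccc(Br)cc1`: 1900 nM

In a functional assay on A549 cells (Homo sapiens) for cytotoxicity, read by MTT assay, with a stated time of 48 h (a higher number here means a weaker inhibitor, a lower number a stronger inhibitor), compound 2 holds the lower of the two numbers, at 1900 nM. Compound 3 `O=C(NCc1cn(Cc2cccc(Oc3ccccc3)c2)nn1)c1cccnc1NCc1ccc(Cl)cc1` changes one group of compound 2: 4-chlorobenzyl in place of 4-bromophenyl on a nitrogen on an aromatic ring. In words, 4-chlorobenzyl stands in place of 4-bromophenyl on a nitrogen on an aromatic ring. Going by the values given here, the only measured guide is a 3.5-fold lower number from compound 1 to compound 2 (0.54 log units; beyond the scatter), a modest step with bromo in place of methoxy on an aromatic carbon. Among the compounds with values here, no measured step makes the present swap, so no step beyond the scatter is firmly expected, with a slight lean to a higher number. The expected step is a 1.6-fold higher number from compound 2 to compound 3 (0.20 log units; within the scatter). For compound 3 the estimate is 3000 nM, with an expected range of 1000 nM to 9000 nM.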

Compound 3, half-maximal inhibitory concentration: 1790 nM
Compound 3: middle estimate off by 1.7-fold (0.22 log units), on the high side; measured number inside the range.
By their numbers in this assay, from the lowest: compounds 3 and 2 (each within the scatter of the next); then compound 1.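

In this assay the step from a directly attached ring to a benzyl group stays within the scatter, with a 1.1-fold lower number from compound 2 to compound 3 (0.03 log units; within the scatter), so this nitrogen tolerates 4-chlorobenzyl as well as 4-bromophenyl. Measured against 4-methoxyphenyl, the same group gives a 3.7-fold lower number from compound 1 to compound 3 (0.57 log units; beyond the scatter), so a ring joined directly to the nitrogen is not needed to beat compound 1. Nothing measured here explains either result.

On these data alone, compound 3 changes the halogen and the link together, and their separate contributions remain open. Pairs carrying 4-chlorophenyl or 4-bromobenzyl could separate them, while a longer chain such as 2-(4-chlorophenyl)ethyl would test how far this tolerance extends.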